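Swapping an ethynyl for bromo on two small aromatic cores

The source may report more compounds than this note shows. Statements on the series, on what has been measured and on what is new or still open speak of the compounds shown alone.

The compounds here were tested in a functional assay on HCT-116 cells (Homo sapiens) for cytotoxicity, with a stated time of 3 days; a higher number here means a weaker inhibitor, a lower number a stronger inhibitor. Compound 1 `C#Cc1nc2ccccc2n1C` gives 19400 nM, and compound 2 `C#CCNC(=O)c1csc(C#C)n1` gives 19200 nM; the two values lie within the usual scatter of each other, and the difference between the two cores is not broken down here. Compound 3 `C#CCNC(=O)c1csc(Br)n1` reaches only a limit of the assay, > 40000 nM. The change from compound 2 to compound 3 is bromo in place of ethynyl on an aromatic carbon and gave an at least 2.0-fold higher number from compound 2 to compound 3 (0.31 log units; beyond the scatter); its exact size is open because of the limit of > 40000 nM in this assay, at which 1 of the 3 values shown sits. Compound 4 `Cn1c(Br)nc2ccccc21` is not yet measured and differs from compound 1 by bromo in place of ethynyl on an aromatic carbon. This is the same kind of change, but on a five-membered aromatic ring with 2 nitrogen, part of a fused system of two rings, between two ring nitrogen atoms and next to the ring atom that bears a methyl group, rather than on a ring with 1 nitrogen and 1 sulfur. Resting on compound 1 at 19400 nM and the step of an at least 2.0-fold higher number from compound 2 to compound 3 (0.31 log units; beyond the scatter), the expected step is a 2.3-fold higher number from compound 1 to compound 4 (0.37 log units; beyond the scatter). Compound 4 is thus estimated at 45000 nM, between 20000 nM and 100000 nM.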

Compound 4, half-maximal inhibitory concentration: > 40000 nM
Compound 4 gave a limit, no number; the forecaster's own chance of this, stated with the estimate: 60%; the middle value lies beyond the limit too.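

In this assay compound 4 gives > 40000 nM as a limit of the assay and not as a number. Bromo in place of ethynyl on an aromatic carbon gave an at least 2.0-fold higher number from compound 1 to compound 4 (0.31 log units; beyond the scatter) on the core of compound 1, so the change carries over in direction between the two cores shown, though only these two pairs support this: the same change on two cores in this assay, an at least 2.0-fold higher number (0.31 log units; beyond the scatter) from compound 2 to compound 3 and an at least 2.0-fold higher number (0.31 log units; beyond the scatter) from compound 1 to compound 4; the limit leaves it open whether they differ. What the two pairs do not show is how large the step is on either core, or whether the change has the same size on both, since both bromo compounds stop at the same limit: the limit of > 40000 nM in this assay, at which 2 of the 4 values shown sit.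

The compounds shown leave open whether another group on the same aromatic carbon, such as chloro, an amine or a nitrile, would behave more like ethynyl or more like bromo. They also leave open whether the same change would point the same way on a third core.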